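The source may hold more compounds than are shown below. What is called first, only, known or untested is meant among the compounds shown, and "the series" means these compounds.

Compound 1 `C=C1C[C@]23C[C@@]1(O)CC[C@H]2c1cc(Br)c(O)c(C)c1[C@@H]3Cn1cc(-c2ccc(Cl)cc2)nn1`: 10500 nM
Compound 2 `C=C1C(=O)[C@]23C[C@@]1(O)CC[C@H]2c1ccc(O)c(C)c1[C@@H]3Cn1cc(-c2ccc(C(F)(F)F)cc2)nn1`: 1110 nM
Compound 3 `C=C1C[C@]23C[C@@]1(O)CC[C@@H]2c1cccc(C)c1[C@@H]3Cn1cc(-c2ccccc2)nn1`: > 20000 nM

All three were tested in a functional assay on A549 cells (Homo sapiens) for cytotoxicity, read by MTT assay, with a stated time of 4 days; a lower number here means a stronger inhibitor, a higher number a weaker inhibitor. Of the two numbers recorded, compound 2 gives the lowest; the nearest number, that of compound 1, sits clearly higher, beyond the usual scatter. Compound 3 gives only a limit of this assay, not a number (the limit of > 20000 nM in this assay, at which 1 of the 3 values shown sits). Compound 4 `C=C1C(=O)[C@]23C[C@@]1(O)CC[C@H]2c1ccc(O)c(C)c1[C@@H]3Cn1cc(-c2ccccc2)nn1` has not yet been measured. It differs from compound 2 in one place: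

hydrogen in place of trifluoromethyl on an aromatic carbon

Going by the values given here, no measured pair differs in just this way, so the size of the step is open. From the change alone, a modest weakening in this assay is expected, a step of a 2.3-fold higher number from compound 2 to compound 4 (0.35 log units; beyond the scatter). Compound 4 is therefore estimated at 2500 nM, between 800 nM and 8000 nM.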

Compound 4, half-maximal inhibitory concentration: 1160 nM
Compound 4: the middle estimate sits 2.2-fold (0.33 log units) above what was measured; the measured number falls inside the stated range.
By their numbers in this assay, from the lowest: compounds 2 and 4 (each within the scatter of the next); then compound 1. At a limit, above all of these: compound 3.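

In this assay, going from 4-(trifluoromethyl)phenyl to phenyl gives a 1.0-fold higher number from compound 2 to compound 4 (0.02 log units; within the scatter). At this place on the aromatic ring, then, trifluoromethyl is not needed to keep the cytotoxic effect seen with compound 2, and plain hydrogen serves equally well. Nothing measured here explains why the two compounds match. On these data alone, what an amine or a carboxylic acid would do at the same place stays open. A single pair also cannot tell whether this swap would behave the same way on the cores of compound 1 or compound 3.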